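A few compounds are considered here, and "the series" means these few. Any claim that something is new, unique, unknown or untested is made for them only; others in the source may bear on it.

Measured in a functional assay on MDA-MB-231 cells (Homo sapiens) for antiproliferative activity, read by MTT assay, with a stated time of 72 h; a lower number here means a stronger inhibitor, a higher number a weaker inhibitor:
- compound 1 `CC(=O)c1ccc(-c2cccc(NC(=O)CCc3ccc4c(c3)COB4O)c2)cc1`: 66000 nM
- compound 2 `COc1cc(OC)cc(-c2cccc(NC(=O)CCc3cccc4c3COB4O)c2)c1`: 93000 nM

With only these two numbers in the series, compound 2 at 93000 nM lies within the usual scatter of compound 1 at 66000 nM. For the measured compounds named here, the two compounds differ in more than one place, so no single-change step has been measured.

The next compound is compound 3 `CC(=O)c1ccc(-c2cccc(NC(=O)CCc3cccc4c3COB4O)c2)cc1`, which keeps the core of compound 2. The change is 4-acetylphenyl in place of 3,5-dimethoxyphenyl on an aromatic carbon, meta to a large group. Going by the values given here, the entering group is the one already carried by compound 1, which gives 66000 nM in this assay.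

Neither measured compound separates the effect of this group from that of the core, so the expectation is weak. No change beyond the scatter is expected, and the expected step is a 1.2-fold lower number from compound 2 to compound 3 (0.07 log units; within the scatter). For compound 3 the estimated value is 80000 nM, with an expected range from 40000 nM to 160000 nM.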

Compound 3, half-maximal inhibitory concentration: 41000 nM
The estimate for compound 3 lay 2.0-fold (0.29 log units) above the measured number; the range from low to high includes it.
By their numbers in this assay, from the lowest: compounds 3, 1 and 2 (each within the scatter of the next, the first and the last beyond it).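

In this assay, for the compounds shown here, at this aromatic carbon, meta to a large group, 4-acetylphenyl in place of 3,5-dimethoxyphenyl gives a 2.3-fold lower number from compound 2 to compound 3 (0.36 log units; beyond the scatter), the first single-place change to clear the scatter, though only modestly. With 4-acetylphenyl held constant, exchanging one boron-bearing group of 10 heavy atoms for the other, on a saturated chain carbon, two bonds along the chain from a carbonyl carbon, gives a 1.6-fold lower number from compound 1 to compound 3 (0.21 log units; within the scatter), so the two groups are not separated in this assay. Nothing available bears on why the aryl exchange moves the number.

Still open, on these data alone, is whether the step follows the acetyl group, the loss of the two methoxy groups, or both, and whether 3,5-dimethoxyphenyl on the core of compound 1 would give the same step as on the core of compound 3. As far as these compounds go, how a phenyl ring carrying an amine or a carboxylic acid would compare at this position is also open, as is the effect of a longer chain between the amide carbonyl and the boron-bearing group.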